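A Nitro Group Replaces Trifluoromethyl on the Benzyl Ether

The compounds below may be only part of what the source reports. "The series", "measured", "known", "first", "only" and "open" are said of these compounds alone.

Within the data shown here, compound 1 `FC(F)(F)c1ccc(COc2cccc(Nc3ncnc4cc5c(cc34)OCCOCCOCCO5)c2)cc1` is the weaker of the two compounds measured so far in a functional assay on SH-SY5Y cells (Homo sapiens) for antiproliferative activity, read by MTT assay, with a stated time of 72 h; a lower number here means a stronger inhibitor, a higher number a weaker inhibitor. In this assay compound 1 gives 20000 nM, the highest of the two numbers in hand, while compound 2 `c1ccc(COc2ccc(Nc3ncnc4cc5c(cc34)OCCOCCOCCOCCO5)cc2)cc1` gives 5250 nM, a gap that lies beyond the usual scatter. Among the measured compounds shown here, compound 2 differs from compound 1 in more than one place, so no single step connects the two.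

For the measured compounds named here, compound 3 `O=[N+]([O-])c1ccc(COc2cccc(Nc3ncnc4cc5c(cc34)OCCOCCOCCO5)c2)cc1` keeps the shared core of compound 1 and changes only one group: nitro in place of trifluoromethyl on an aromatic carbon The trifluoromethyl leaves an aromatic carbon para to a large group, and a nitro enters at the same place. Going by the values given here, no measured pair shows what this exchange does here. Without such a pair to lean on, the expectation is a small step, a 1.3-fold lower number from compound 1 to compound 3 (0.12 log units; within the scatter), with no direction that would stand out from the scatter. Compound 3 is estimated at 15000 nM, with a range from 5000 nM to 40000 nM.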

Compound 3, half-maximal inhibitory concentration: > 100000 nM
Compound 3 was reported as a limit (the forecaster's own chance of this, stated with the estimate: 20%); middle value at least 6.6-fold (0.82 log units) away from the limit.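

Going from 4-(trifluoromethyl)benzyl to 4-nitrobenzyl gives the first step in this assay that rests on a single change, and that change is not neutral: it produces an at least 5.0-fold higher number from compound 1 to compound 3 (0.69 log units; beyond the scatter). The place para to a large group is therefore sensitive to which of these two groups it carries, and of the pair, nitro gives the weaker compound. The reading for compound 3 is a limit and not a number, so the full size of the step stays unknown: the limit of > 100000 nM in this assay, at which 1 of the 3 values shown sits.

The compounds shown leave open whether an amine, a nitrile or a methoxy group at this same place would stay close to compound 1 or fall away as compound 3 does. Nor do they show how the same exchange would read on the core of compound 2.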